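The source may hold more compounds than are shown below. What is called first, only, known or untested is meant among the compounds shown, and "the series" means these compounds.

Measured compounds:
- compound 1, `O=C(O)Cn1nc(Cc2nc3cc(Cl)c(OC(F)(F)F)cc3[nH]2)c2ccccc2c1=O`: 342 nM
- compound 2, `COc1cc(OC)c(NC(=O)Cn2nc(CC(=O)O)c3ccccc32)cc1Cl`: 8980 nM
- compound 3, `C[C@H](C(=O)O)n1nc(Cn2cc3cc(OCC4CC4)c(Cl)cc3n2)c2ccccc2c1=O`: 15 nM

In a functional assay on CHO cells for antagonist activity at sphingosine 1-phosphate receptor 2 (Homo sapiens), read by GTPgammaS binding (on this read-out lower numbers stand for stronger inhibition and higher numbers for weaker inhibition), compound 1 gives 342 nM, which places it second highest of the three numbers shown. Compound 3 gives 15 nM, a lower number that lies beyond the scatter, and compound 2 gives 8980 nM, a higher number also beyond the scatter. Going by the values given here, compound 3 differs from compound 1 in more than one place, so the two values only show that compound 3 is the stronger inhibitor of the pair; no single step is drawn between them.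

Compound 4, `O=C(O)Cn1nc(Cc2nc3cc(Cl)c(OCC4CC4)cc3[nH]2)c2ccccc2c1=O`, has not yet been measured. It differs from compound 1 by cyclopropylmethyl in place of trifluoromethyl on an oxygen on an aromatic ring, the same difference read one bond further out being trifluoromethoxy to cyclopropylmethoxy. Among the compounds with values here, no measured pair isolates this change. The writer expects compound 4 to give a moderately lower number than compound 1, by a step of a 3.1-fold lower number from compound 1 to compound 4 (0.49 log units; beyond the scatter) that reaches beyond the scatter but stays well short of the gap to compound 3. Compound 4 is accordingly estimated at 110 nM, with a range from 30 nM to 400 nM.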

Compound 4, half-maximal inhibitory concentration in the sphingosine 1-phosphate receptor 2 assay: 25 nM
The estimate for compound 4 lay 4.4-fold (0.64 log units) above the measured number, outside the stated range (below it).
By their numbers in the sphingosine 1-phosphate receptor 2 assay, from the lowest: compounds 3 and 4 (each within the scatter of the next); then compound 1; then compound 2.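

In the sphingosine 1-phosphate receptor 2 assay, cyclopropylmethyl in place of trifluoromethyl on an oxygen on an aromatic ring gives a 14-fold lower number from compound 1 to compound 4 (1.14 log units; beyond the scatter). Going by these compounds alone, this is the first step here that isolates a single change, and it shows that the group on this oxygen has a large bearing on the read-out, although the two groups have the same count of heavy atoms. In a physicochemical assay for lipophilicity, at pH 7.4 (a higher number here means a more lipophilic compound, a lower number a more polar compound), compound 1 gives 2.54 and compound 4 gives 2.21 on the same read-out. The stronger inhibitor of the pair is also the less lipophilic in the physicochemical assay, so on this pair the gain in inhibition does not come with a rise in lipophilicity: the measured distribution coefficient of compound 1, 2.54, and of compound 4, 2.21, a number 0.33 log units lower (beyond the scatter)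

A single pair cannot tell whether the three-membered ring or the loss of the fluorine atoms carries the step, which leaves open how a plain ethyl, a longer chain or a cyclobutylmethyl group on the same oxygen would read. It also leaves open whether the same change would give a step of this size on a core other than that of compound 1.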